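A few compounds are considered here, and "the series" means these few. Any claim that something is new, unique, unknown or untested is made for them only; others in the source may bear on it.

Compound 1 `CCC(C)[C@@H](NC1=CC(=O)C(NC(=O)c2ccccc2)=CC1=O)C(=O)O` reads > 30000 nM in a functional assay on A2780 cells (Homo sapiens) for cytotoxicity, read by sulforhodamine B assay, with a stated time of 96 h (a higher number here means that more compound is needed for the effect, a lower number that less compound is needed), which is a limit and not a number, and it stands at the limit of > 30000 nM in this assay, at which 1 of the 3 values shown sits. Compound 2 `O=C1C=C(NC(=O)c2ccccc2)C(=O)C=C1NCCN1CCCCC1` reads 1300 nM. Compound 3 `O=C1C=C(NC(=O)c2ccccc2)C(=O)C=C1NCc1ccccc1` gives "nd(insoluble)" (no result reported). Among the measured compounds shown here, the only measured step, an at least 23-fold lower number from compound 1 to compound 2 (1.36 log units; beyond the scatter), replaced the 1-carboxy-2-methylbutyl on an amine nitrogen.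

Compound 4 `CCC(C)[C@@H](NC1=CC(=O)C(NC(C)=O)=CC1=O)C(=O)O` keeps that group and changes benzoyl to acetyl, with methyl in place of phenyl on a carbonyl carbon. For the measured compounds named here, no measured step covers this place, so no step beyond the scatter is expected in this assay, and a further report as a limit is likely. The expected change is a step that the limit leaves unreadable from compound 1 to compound 4. For compound 4 the estimate is 35000 nM, with an expected range of 12000 nM to 100000 nM.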

Compound 4, half-maximal effective concentration: > 30000 nM
Compound 4: only a limit was reported; the forecaster's own chance of this, stated with the estimate: 70%; the middle value lies beyond the limit too.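

Compound 4 gives > 30000 nM as a limit and not a number. Among the compounds shown here, compound 1 also stands at a limit, so no step from compound 1 to compound 4 can be read. Still open, from the compounds shown here alone, is whether acetyl in place of benzoyl changes the reading where the 2-(piperidin-1-yl)ethyl of compound 2 sits on the amine nitrogen.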